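Trifluoromethoxy in Place of Trifluoromethyl on the Phenyl

The source may report more compounds than this note shows. Statements on the series, on what has been measured and on what is new or still open speak of the compounds shown alone.

Measured compounds:
Compound 1 `COc1cc2c(Oc3ccc(NC(=O)c4nn(-c5ccccc5)c(=O)cc4C)cc3F)ccnc2cc1OCCCN1CCCCC1` gives 150 nM in a functional assay on A549 cells (Homo sapiens) for inhibition, read by MTT assay, with a stated time of 72 h; a lower number here means a stronger inhibitor, a higher number a weaker inhibitor.
Compound 2 `COc1cc2c(Oc3ccc(NC(=O)c4nn(-c5ccccc5C(F)(F)F)c(=O)cc4C)cc3F)ccnc2cc1OCCCN1CCCCC1` gives 140 nM in this assay.

Of the two numbers, compound 2 holds the lowest, but the step of a 1.1-fold lower number from compound 1 to compound 2 (0.03 log units; within the scatter) lies within the scatter, so nothing separates the two compounds. Compound 3 `COc1cc2c(Oc3ccc(NC(=O)c4nn(-c5ccccc5OC(F)(F)F)c(=O)cc4C)cc3F)ccnc2cc1OCCCN1CCCCC1` differs from compound 2 by trifluoromethoxy in place of trifluoromethyl on an aromatic carbon. Among the measured compounds shown here, no measured step swaps trifluoromethyl for trifluoromethoxy at this carbon. For the measured compounds named here, the only measured step, a 1.1-fold lower number from compound 1 to compound 2 (0.03 log units; within the scatter), shows that placing trifluoromethyl on the phenyl where hydrogen stood left the number essentially unchanged, and compound 3 keeps a fluorinated group of similar size at the same carbon. A step in this assay beyond the scatter is therefore not expected in either direction. Compound 3 is estimated at 140 nM, with a range from 70 nM to 280 nM. That expected change is no change at the digits printed from compound 2 to compound 3 (within the scatter).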

Compound 3, half-maximal inhibitory concentration: 120 nM
Estimate against measurement, compound 3: 1.2-fold (0.07 log units) above; low and high end bracket the measured number.
By their numbers in this assay, from the lowest: compounds 3, 2 and 1 (each within the scatter of the next).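

In this assay the swap at this aromatic carbon gives a 1.2-fold lower number from compound 2 to compound 3 (0.07 log units; within the scatter) and so adds a second fluorinated group that cannot be told apart from trifluoromethyl, even with an oxygen now linking it to the ring. Set against hydrogen at the same carbon, trifluoromethoxy gives a 1.3-fold lower number from compound 1 to compound 3 (0.10 log units; within the scatter) and so, like trifluoromethyl, cannot be told apart from the unsubstituted phenyl, which puts all three compounds within the scatter of one another. Nothing measured here bears on why these three groups read alike.

On these data alone, whether an amine, a carboxylic acid or a longer chain at this carbon would stay within the same range remains open. As far as these compounds go, it is also open whether trifluoromethyl and trifluoromethoxy would read alike on other carbons of this ring.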